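The source may hold more compounds than are shown below. What is called first, only, known or untested is meant among the compounds shown, and "the series" means these compounds.

Compound 1, `FC(F)(F)c1ccc(CSc2nc(Nc3ccccc3C(F)(F)F)c3ccccc3n2)cc1` — > 50000 nM; compound 2, `Cc1ccccc1Nc1nc(SCc2ccc(C(F)(F)F)cc2)nc2ccccc12` — 27500 nM; compound 3, `FC(F)(F)c1ccc(CSc2nc(Nc3cccc(Br)c3)c3ccccc3n2)cc1` — 18300 nM.

The three compounds share one core and differ only in the aryl group carried on the ring nitrogen. In a functional assay on HGC-27 cells (Homo sapiens) for cytotoxicity, read by MTT assay, with a stated time of 72 h (a lower number here means a stronger inhibitor, a higher number a weaker inhibitor), compound 1 gives > 50000 nM, which is a limit of the assay rather than a number, (the limit of > 50000 nM in this assay, at which 1 of the 3 values shown sits). In this assay compound 2 gives 27500 nM and compound 3 gives 18300 nM. Compound 3 holds the lowest of the two numbers; its nearest neighbour is compound 2, and the two sit within the scatter of each other. The recorded steps are an at least 1.8-fold lower number from compound 1 to compound 2 (0.25 log units; that floor lies within the scatter), an at least 2.7-fold lower number from compound 1 to compound 3 (0.43 log units; beyond the scatter) and a 1.5-fold lower number from compound 2 to compound 3 (0.18 log units; within the scatter).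

Compound 4, `O=[N+]([O-])c1ccc(Nc2nc(SCc3ccc(C(F)(F)F)cc3)nc3ccccc23)cc1`, is not yet measured. It differs from compound 3 in one place: 4-nitrophenyl in place of 3-bromophenyl on a nitrogen on an aromatic ring. Both steps that end at compound 3 alter the same aryl group on that nitrogen, and neither went far: one is bounded by a limit, the other stays within the scatter. On that basis no step beyond the scatter is expected in this assay, in either direction. Compound 4 is therefore expected to give 20000 nM in this assay, between 8000 nM and 50000 nM. The estimate for compound 4 means a 1.1-fold higher number from compound 3 to compound 4 (0.04 log units; within the scatter).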

Compound 4, half-maximal inhibitory concentration: 16600 nM
For compound 4 the middle estimate is 1.2-fold (0.08 log units) above the measured one; low and high end bracket the measured number.
By their numbers in this assay, from the lowest: compounds 4, 3 and 2 (each within the scatter of the next). At a limit, above all of these: compound 1.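

The change from 3-bromophenyl to 4-nitrophenyl on the nitrogen gives a 1.1-fold lower number from compound 3 to compound 4 (0.04 log units; within the scatter) in this assay, and the change from 2-methylphenyl gives a 1.7-fold lower number from compound 2 to compound 4 (0.22 log units; within the scatter), so a nitro-bearing aryl group, which brings hydrogen-bond acceptors absent from 3-bromophenyl, joins the two earlier measured compounds without separating from either. Against 2-(trifluoromethyl)phenyl the new group gives an at least 3.0-fold lower number from compound 1 to compound 4 (0.47 log units; beyond the scatter), and this floor, like the one for compound 3, lies beyond the scatter, whereas the floor for compound 2 does not, so the separation from compound 1 does not hold for every aryl group shown. The value of compound 1 is a limit of the assay and not a number: the limit of > 50000 nM in this assay, at which 1 of the 4 values shown sits.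

Since this change alters both the substituent and where it sits on the phenyl ring, the two cannot be told apart here, and 3-nitrophenyl or 4-bromophenyl on the same nitrogen would be needed to separate them. On these data alone, how an amine or a carboxylic acid on that phenyl ring would read in this assay remains open, as does any change elsewhere on the shared core.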